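The compounds below may be only part of what the source reports. "The series", "measured", "known", "first", "only" and "open" are said of these compounds alone.

Among the measured compounds shown here, compound 2 `C=CCc1cc(C(C)=O)c(O)cc1OCCCCCCCCC#N` gives 50% in an assay on isolated protein for binding affinity to leukotriene B4 receptor 1 (Homo sapiens), tested at 1 uM (a lower number here means less inhibition, a higher number more inhibition at the concentration tested (going by the name of the read-out)), the higher of the two numbers so far, while compound 1 `C=CCc1cc(C(C)=O)c(O)cc1OCCCC#N` gives 6%. For the measured compounds named here, the only measured step, a number 44 percentage points higher from compound 1 to compound 2 (beyond the scatter), came with lengthening a nitrile-tipped chain. Compound 3 `C=CCc1cc(C(C)=O)c(O)cc1OCCCCC` differs from compound 2 by hydrogen in place of 3-cyanopropyl on a saturated chain carbon, five bonds along the chain from an oxygen on an aromatic ring, so the chain is both shortened and loses its nitrile. Going by the values given here, with only that one step to go on, a drop is expected, estimated at a number 30 percentage points lower from compound 2 to compound 3 (beyond the scatter). Compound 3 is thus expected to give 20%, with a range from 3% to 42%.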

Compound 3, a percentage reported as inhibition, at one concentration (the size of the read-out at that concentration, not a potency): 23%
The estimate for compound 3 lay 3 percentage points below the measured number; the range from low to high includes it.
By their numbers in this assay, from the lowest: compound 1; then compound 3; then compound 2.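

A chain with no nitrile still registers in this assay: replacing the cyano of the short chain with ethyl gives a number 17 percentage points higher from compound 1 to compound 3 (beyond the scatter), so this position does not need a nitrile for inhibition. Even so, replacing 3-cyanopropyl with hydrogen gives a number 27 percentage points lower from compound 2 to compound 3 (beyond the scatter), so the plain chain does not match the longest one. Nothing available explains either shift.

Chain length and the nitrile change together in these steps, so their shares remain unseparated. As far as these compounds go, a longer chain without the nitrile, or one ending in an amine or a carboxylic acid, remains open.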